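Benzyl to 3-chlorobenzyl on the shared core

The source may hold more compounds than are shown below. What is called first, only, known or untested is meant among the compounds shown, and "the series" means these compounds.

Among the measured compounds shown here, compound 1 `CC1(C)c2[nH]nc(NC(=O)c3ccccc3)c2CN1Cc1ccccc1` is the unsubstituted parent of the set; in an assay on Sf21 cells for inhibition of high affinity nerve growth factor receptor (Homo sapiens), read by HTRF, with a stated time of 30 min, in the presence of a further agent that is not named here (on this read-out higher numbers stand for weaker inhibition and lower numbers for stronger inhibition), compound 1 gives 1240 nM, the highest of the three numbers measured so far, though the other two stand within the scatter of it. Compound 2 `CC1(C)c2[nH]nc(NC(=O)c3ccccc3)c2CN1Cc1cccc(C#N)c1` carries cyano in place of hydrogen on an aromatic carbon of the benzyl group and gives 980 nM; compound 3 `CC1(C)c2[nH]nc(NC(=O)c3ccccc3)c2CN1Cc1cccc(Br)c1` carries bromo in place of hydrogen on an aromatic carbon and gives 940 nM. The steps are small: a 1.3-fold lower number from compound 1 to compound 2 (0.10 log units; within the scatter) and a 1.3-fold lower number from compound 1 to compound 3 (0.12 log units; within the scatter), and between the two substituted compounds a 1.0-fold lower number from compound 2 to compound 3 (0.02 log units; within the scatter). Compound 4 `CC1(C)c2[nH]nc(NC(=O)c3ccccc3)c2CN1Cc1cccc(Cl)c1` differs from compound 1 by chloro in place of hydrogen on an aromatic carbon. The two measured steps from compound 1 bear directly on this change, and neither leaves the scatter, so for compound 4 no step beyond the scatter is expected in this assay in either direction. Compound 4 is therefore estimated at 950 nM, in the range 500 nM to 1800 nM. The expected step is a 1.3-fold lower number from compound 1 to compound 4 (0.12 log units; within the scatter), an estimate only.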

Compound 4, half-maximal inhibitory concentration: 670 nM
Compound 4: middle estimate off by 1.4-fold (0.15 log units), on the high side, and the stated range covers the measured number.
By their numbers in this assay, from the lowest: compounds 4, 3, 2 and 1 (each within the scatter of the next).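

Chloro gives a 1.9-fold lower number from compound 1 to compound 4 (0.27 log units; within the scatter) in this assay, so three different groups at this position of the benzyl group now stay within the scatter of the unsubstituted parent. Exchanging one substituent for another is no more telling, with a 1.4-fold lower number from compound 3 to compound 4 (0.15 log units; within the scatter) and a 1.5-fold lower number from compound 2 to compound 4 (0.17 log units; within the scatter), which means chloro, bromo and cyano cannot be told apart at this position. No supporting data are available to explain these numbers.

The compounds shown leave open whether any group at this position can move the number beyond the scatter, for example an amine, a carboxylic acid or a longer chain. They also leave open whether chloro elsewhere on the six-membered aromatic ring of the benzyl group would stay within the scatter of compound 1.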